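A few compounds are considered here, and "the series" means these few. Any claim that something is new, unique, unknown or untested is made for them only; others in the source may bear on it.

Series notes, adenosine receptor A3 binding. Three compounds built on the shared aminothiophene ketone core have been run in an assay on CHO cells for displacement of a labelled ligand from adenosine receptor A3 (Homo sapiens), read by scintillation counting, with a stated time of 120 min, tested at 10 uM; on this read-out higher numbers stand for more inhibition at the one concentration tested (going by the name of the read-out) and lower numbers for less inhibition. Compound 1 `Nc1scc(CN2CCC(c3ccc(Cl)cc3)CC2)c1C(=O)c1ccc(Cl)cc1` gives 6% in this assay. Compound 2 `Nc1scc(CN2CCN(c3ccc(C(F)(F)F)cc3)CC2)c1C(=O)c1cccc(C(F)(F)F)c1` gives 0% in this assay. Compound 3 `Nc1scc(CN2CCN(C3CCCC3)CC2)c1C(=O)c1ccc(Cl)cc1` gives 3% in this assay. Compound 3 thus sits with compound 1 and compound 2 in a cluster of small numbers; its separation from compound 1 and from compound 2 is in each case within the usual scatter, so no ordering among the three can be read from these figures.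

Compound 4 `Nc1scc(CN2CCN(c3c(Cl)cccc3Cl)CC2)c1C(=O)c1ccc(Cl)cc1` has not yet been measured. Relative to compound 3 the difference is 2,6-dichlorophenyl in place of cyclopentyl on an amine nitrogen in a ring, with everything else held the same. None of the three measured compounds, whatever the group on that ring nitrogen, shows displacement beyond the scatter, so the step from compound 3 to compound 4 in this assay is expected to be small, in either direction or none at all, about a number 2 percentage points higher from compound 3 to compound 4 (within the scatter). Compound 4 is estimated at 5% in this assay, with a range from -5% to 20%.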

Compound 4, a percentage reported as inhibition, at one concentration (the size of the read-out at that concentration, not a potency): 1%
The estimate for compound 4 lay 4 percentage points above the measured number; the measured number falls inside the stated range.
By their numbers in this assay, from the lowest: compounds 2, 4, 3 and 1 (each within the scatter of the next).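

In this assay, going by these compounds alone, 2,6-dichlorophenyl in place of cyclopentyl on an amine nitrogen in a ring gives a number 2 percentage points lower from compound 3 to compound 4 (within the scatter), the first comparison that isolates a change at one place. At this position, an aromatic ring carrying two chlorines and a non-aromatic ring of carbon only therefore cannot be told apart, and the larger group brings no displacement beyond the scatter. No accompanying data bear on this result.

Open, going by these compounds, is whether a carboxylic acid or a longer alkyl chain on this ring nitrogen would move the number beyond the scatter from that of compound 3. Also open, on these data alone, is whether a change elsewhere on the shared core, such as an amide in place of the ketone carbonyl, would do so.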